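This account rests on a few compounds, and the source may have more. Where it says the series, first, only, none or still open, it means among the compounds named here.

Measured so far:
compound 1 `COc1cc(-c2nn(-c3cccc(NC(=O)Nc4ccc(Cl)c(Cl)c4)c3)cc2-c2ccncc2)ccc1Cl`: 945 nM
compound 2 `O=C(Nc1cccc(-n2cc(-c3ccncc3)c(-c3ccc(Cl)c(O)c3)n2)c1)Nc1ccc(Cl)c(Cl)c1`: 1060 nM

In a functional assay on MCF7 cells (Homo sapiens) for inhibition, read by sulforhodamine B assay, with a stated time of 48 h (on this read-out lower numbers stand for stronger inhibition of growth and higher numbers for weaker inhibition of growth), compound 1 gives 945 nM, and compound 2 gives 1060 nM. The two differ only in hydrogen in place of methyl on an oxygen on an aromatic ring, and the step of a 1.1-fold higher number from compound 1 to compound 2 (0.05 log units; within the scatter) lies within the scatter, so compound 1 stands level with compound 2 on the numbers shown. Compound 3 `COc1cc(-c2nn(-c3cccc(NC(=O)c4ccccc4)c3)cc2-c2ccncc2)ccc1Cl` has not yet been measured. It differs from compound 1 by phenyl in place of (3,4-dichlorophenyl)amino on a carbonyl carbon. Going by the values given here, no measured step touches this part of the molecule; the one known step concerns a different position and does not bear on it. The expectation therefore rests on the change itself, which takes away the hydrogen-bond donor of the leaving group, and a weaker growth inhibition, a higher number, is expected for compound 3, as a 3.7-fold higher number from compound 1 to compound 3 (0.57 log units; beyond the scatter). Compound 3 is estimated at 3500 nM, with a range from 900 nM to 15000 nM.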

Compound 3, concentration for 50% growth inhibition: 335 nM
Estimate against measurement, compound 3: 10-fold (1.02 log units) above, outside the stated range (below it).
By their numbers in this assay, from the lowest: compound 3; then compounds 1 and 2 (each within the scatter of the next).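

In this assay, putting phenyl in place of (3,4-dichlorophenyl)amino on the carbonyl carbon gives a 2.8-fold lower number from compound 1 to compound 3 (0.45 log units; beyond the scatter), so the number responds to this part of the molecule, which the step between the first two compounds, made elsewhere, could not show, and the group with fewer heavy atoms and no hydrogen-bond donor gives the stronger growth inhibition. This single step removes the amino nitrogen and both chlorine atoms together, so it cannot tell which of these losses matters. Nothing measured here explains the shift. Still open, on these data alone, is how the number moves with other groups on this carbonyl carbon, such as a methyl group, a cyclohexyl ring or a longer alkyl chain. Also open, as far as these compounds go, is whether hydrogen in place of methyl on the oxygen changes as little with phenyl present.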